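Working notes: bromo for trifluoromethyl in compound 4

This account rests on a few compounds, and the source may have more. Where it says the series, first, only, none or still open, it means among the compounds named here.

- compound 1 `Cc1ccc(NC(=O)C2CCN(C/C=C/c3ccccc3)CC2)cc1`: 29600 nM
- compound 2 `COc1cccc(NC(=O)C2CCN(C/C=C/c3ccccc3)CC2)c1`: 50500 nM
- compound 3 `O=C(Nc1cccc(C(F)(F)F)c1)C1CCN(C/C=C/c2ccccc2)CC1`: 15600 nM

In a functional assay on A549 cells (Homo sapiens) for inhibition, read by MTT assay, with a stated time of 72 h (on this read-out higher numbers stand for weaker inhibition and lower numbers for stronger inhibition), compound 3 gives 15600 nM, which lies within the usual scatter of compound 1 at 29600 nM. Compound 3 is separated from compound 2 by a gap beyond the scatter, seen in the step of a 3.2-fold lower number from compound 2 to compound 3 (0.51 log units; beyond the scatter).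

The next compound, compound 4 `O=C(Nc1cccc(Br)c1)C1CCN(C/C=C/c2ccccc2)CC1`, carries bromo in place of trifluoromethyl on an aromatic carbon. For the measured compounds named here, no measured compound carries bromo, so the evidence is indirect. Going by the values given here, two measured steps bear on the change. The closer one is a 3.2-fold lower number from compound 2 to compound 3 (0.51 log units; beyond the scatter), with trifluoromethyl in place of methoxy on an aromatic carbon, and it is modest. The other is a 1.7-fold higher number from compound 1 to compound 2 (0.23 log units; within the scatter), which does not exceed the scatter. Changes of aromatic substituent in this small set have therefore stayed small, and no large step is expected in this assay. The expected step is a 1.2-fold higher number from compound 3 to compound 4 (0.06 log units; within the scatter), and no clear direction is anticipated beyond the scatter.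

Compound 4 is estimated at 18000 nM, with an expected range of 8000 nM to 40000 nM.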

Compound 4, half-maximal inhibitory concentration: 16500 nM
Compound 4: middle estimate off by 1.1-fold (0.04 log units), on the high side, and the stated range covers the measured number.
By their numbers in this assay, from the lowest: compounds 3, 4, 1 and 2 (each within the scatter of the next, the first and the last beyond it).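

Working notes on the result: in this assay, a 1.1-fold higher number from compound 3 to compound 4 (0.02 log units; within the scatter) shows that, on this aromatic carbon meta to a large group, 1 heavy atom of bromo can replace the 4 heavy atoms of trifluoromethyl with no step that stands out from the scatter. Bromo also reproduces the separation from methoxy that trifluoromethyl gave, with a 3.1-fold lower number from compound 2 to compound 4 (0.49 log units; beyond the scatter), so that gap no longer rests on trifluoromethyl alone, and compound 2 stands apart from both compound 3 and compound 4. By contrast, a 1.8-fold lower number from compound 1 to compound 4 (0.25 log units; within the scatter), a comparison of 3-bromophenyl with 4-methylphenyl on the amide-type nitrogen, does not separate the two compounds, so the set gives no sign that 3-bromophenyl differs from 4-methylphenyl on this read-out.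

No measurement is available that could explain why bromo and trifluoromethyl read alike here. Still open, going by these compounds, is whether an amine, a carboxylic acid or a longer chain on this same aromatic carbon would give a number clearly apart from those of compound 3 and compound 4.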